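A Third Methoxy Group on the Core of Compound 1

A few compounds are considered here, and "the series" means these few. Any claim that something is new, unique, unknown or untested is made for them only; others in the source may bear on it.

Among the measured compounds shown here, compound 1 `COc1ccc(C2SCC(=O)N2NC(=O)CNC(=O)c2ccccc2)cc1OC` is one of three compounds measured in a physicochemical assay for lipophilicity; a lower number here means a more polar compound, a higher number a more lipophilic compound. In this assay compound 1 gives 1.85, the lowest of the three numbers. Compound 2 `O=C(CNC(=O)c1ccccc1)NN1C(=O)CSC1c1ccccc1` stands nearest, and in this assay compound 2 gives 1.95, a number within the scatter of compound 1. Compound 3 `O=C(CNC(=O)c1ccccc1)NN1C(=O)CSC1c1ccc(F)cc1` stands furthest, and in this assay compound 3 gives 2.1, also within the scatter of compound 1. For the measured compounds named here, the only step between measured compounds that differ in a single place runs a number 0.15 log units higher from compound 2 to compound 3 (within the scatter); it concerns a fluoro in place of hydrogen rather than a methoxy group, so it offers little direct guidance here.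

Compound 4 `COc1cc(C2SCC(=O)N2NC(=O)CNC(=O)c2ccccc2)cc(OC)c1OC` is not yet measured. It differs from compound 1 in one place: methoxy in place of hydrogen on an aromatic carbon. Going by the values given here, no measured pair shows exactly this change. Compound 1 carries two methoxy groups where compound 2 carries none, yet the two values lie within the scatter of each other, which gives no sign that a further methoxy group would move the number beyond the scatter. For compound 4 in this assay the expected step is therefore a number 0.05 log units higher from compound 1 to compound 4 (within the scatter), no larger than the scatter. The estimate for compound 4 is 1.9, expected to lie between 1.5 and 2.3.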

Compound 4, partition coefficient: 1.65
For compound 4 the middle estimate is 0.25 log units above the measured one; low and high end bracket the measured number.
By their numbers in this assay, from the lowest: compounds 4, 1, 2 and 3 (each within the scatter of the next, the first and the last beyond it).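

Among the compounds shown here, this is the first direct reading of methoxy in place of hydrogen on an aromatic carbon: in this assay, the step runs a number 0.20 log units lower from compound 1 to compound 4 (within the scatter). At this position, ortho to a methoxy group, meta to a second methoxy group and meta to a large group, the change therefore does not separate the two compounds in this read-out, and a single pair cannot establish a direction for it. Nothing measured here explains the size or the sign of this step, so the result stands as an observation about this one pair.

The compounds shown leave open whether an amine or a carboxylic acid on this same aromatic carbon, or ethoxy as a longer chain in place of the new methoxy group, would give a step beyond the scatter. They also leave open whether methoxy in place of hydrogen would give a similar step on the ring of compound 2, which carries no methoxy group, or at another place on the ring of compound 1.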